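Vero cell cytotoxicity notes: from compound 3 to compound 4

A few compounds are considered here, and "the series" means these few. Any claim that something is new, unique, unknown or untested is made for them only; others in the source may bear on it.

Compound 1, `CN(C)C(=O)C[C@H](CSc1ccccc1)Nc1c(C(=O)N/N=C/c2ccccc2F)cnc2c(C(F)(F)F)cccc12`, gives in an ADME assay on Vero cells (Chlorocebus sabaeus) for cytotoxicity, read by MTT assay, with a stated time of 72 h (a lower number here means a stronger inhibitor, a higher number a weaker inhibitor), only a limit, > 62.5 ug/mL.
Compound 2, `CN(C)C(=O)C[C@H](CSc1ccccc1)Nc1c(C(=O)N/N=C/c2ccc(Br)s2)cnc2c(C(F)(F)F)cccc12`, gives in this assay only a limit, > 62.5 ug/mL.
Compound 3, `CN(C)C(=O)C[C@H](CSc1ccccc1)Nc1c(C(=O)N/N=C/c2ccccc2F)cnc2ccc(F)cc12`, gives in this assay only a limit, > 62.5 ug/mL.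

Compound 3 thus stands at the same limit as the two other values shown; no number separates it from them. Going by the values given here, the one step between measured compounds that differ in a single place, a step that the two limits leave unreadable from compound 1 to compound 2, is left unreadable by the two limits. The evidence on the measured steps is therefore confined to the limit of > 62.5 ug/mL in this assay, at which 3 of the 3 values shown sit.

Compound 4, `CN(C)C(=O)C[C@H](CSc1ccccc1)Nc1c(C(=O)N/N=C/c2ccc(OC(F)(F)F)cc2)cnc2ccc(F)cc12`, is not yet measured. It differs from compound 3 by 4-(trifluoromethoxy)phenyl in place of 2-fluorophenyl on a carbon with a double bond to nitrogen. Among the compounds with values here, no measured step exchanges the group on that carbon for a 4-(trifluoromethoxy)phenyl, and the one step that exchanges the group on the same carbon with a double bond to nitrogen is unreadable, so it gives no size to borrow. Nothing in the measured values points to a step beyond the scatter in either direction; the expectation for a step that the limit leaves unreadable from compound 3 to compound 4 is no readable change. Compound 4 is accordingly expected to give in this assay about 90 ug/mL, with a range from 50 ug/mL to 250 ug/mL, most likely again reported only as a limit.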

Compound 4, half-maximal inhibitory concentration: > 62.5 ug/mL
Compound 4: only a limit was reported (the forecaster's own chance of this, stated with the estimate: 85%); the middle value lies beyond the limit too.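

Going by these compounds alone, compound 3 and compound 4 are both reported only as limits in this assay, and no step between them can be read. The compounds shown leave open where a numerical half-maximal inhibitory concentration would lie for any member of the series, and whether the group on the carbon with a double bond to nitrogen alters it: the limit of > 62.5 ug/mL in this assay, at which 4 of the 4 values shown sit.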